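Replacing 2-bromo-6-chlorophenyl with 4-methylphenyl: an expected permeability

The compounds below may be only part of what the source reports. "The series", "measured", "known", "first", "only" and "open" are said of these compounds alone.

Two compounds sharing one core have been taken through a physicochemical assay for permeability, using PAMPA; on this read-out higher numbers stand for higher permeability and lower numbers for lower permeability. Compound 1 `Cc1oc(-c2ccc(Cl)cc2)nc1CN1CCC(C(=O)NCCCN2C[C@H](C)C[C@H](C)C2)CC1` gives > 635 10^-6 cm/s, and this reading is a limit of the assay and not a number. On these data alone, compound 2 `Cc1oc(-c2c(Cl)cccc2Br)nc1CN1CCC(C(=O)NCCCN2C[C@H](C)C[C@H](C)C2)CC1` has no number to offer, its entry being "not determined" (no result reported), so its place on the scale remains open.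

Compound 3 `Cc1ccc(-c2nc(CN3CCC(C(=O)NCCCN4C[C@H](C)C[C@H](C)C4)CC3)c(C)o2)cc1` has yet to be measured. The change that leads to it is 4-methylphenyl in place of 2-bromo-6-chlorophenyl on an aromatic carbon, with 4-methylphenyl in place of 2-bromo-6-chlorophenyl on an aromatic carbon of the five-membered aromatic ring. With no number for compound 2, the step in this assay has no starting value, and neither its size nor its direction can be read from the data. Going by the values given here, the only guide is compound 1 at its limit of > 635 10^-6 cm/s. On that slender basis, compound 3 is expected to read high on this scale, with no departure beyond the scatter from that limit. For compound 3 the estimated value is 500 10^-6 cm/s, with an expected range from 150 10^-6 cm/s to 800 10^-6 cm/s.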

Compound 3, apparent permeability: 274 10^-6 cm/s
Compound 3: the middle estimate sits 1.8-fold (0.26 log units) above what was measured; the measured number falls inside the stated range.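

Going by these compounds alone, compound 3 gives the first plain number for this series in this assay, and it shows that a single swap on the phenyl group at this place on the five-membered aromatic ring can move the reading beyond the scatter. Between two compounds that differ in one place, methyl in place of chloro on an aromatic carbon goes with an at least 2.3-fold lower number from compound 1 to compound 3 (0.36 log units; beyond the scatter). Compound 1 stands at a limit of the assay, > 635 10^-6 cm/s, and the step can be given only as a minimum because one end of it rests on that limit: the limit of > 635 10^-6 cm/s in this assay, at which 1 of the 3 values shown sits.

On these data alone, the step between compound 2 and compound 3 cannot be read, so how 2-bromo-6-chlorophenyl compares with 4-methylphenyl at this place stays open in this assay. Also open, as far as these compounds go, is how far the reading would move with an amine or a carboxylic acid in place of the methyl group of 4-methylphenyl, and whether such a group would carry the number further from that of compound 3.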